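A few compounds are considered here, and "the series" means these few. Any claim that something is new, unique, unknown or untested is made for them only; others in the source may bear on it.

Measured so far in the series:

Compound 1, `O=C(Nc1ccccc1Br)N[C@@H]1CCN(c2cccc(F)c2)C1`: in a functional assay for antagonist activity at transient receptor potential cation channel subfamily V member 1 (Rattus norvegicus), read by FLIPR (a higher number here means a more potent compound, by a factor of ten per unit of this negative logarithm, a lower number a less potent compound), compound 1 gives 7.8
Compound 2, `O=C(Nc1ccccc1Br)N[C@@H]1CCN(c2ccc(F)c(F)c2)C1`: in this assay compound 2 gives 8.1
Compound 3, `O=C(Nc1ccccc1Br)N[C@@H]1CCN(c2ccc(Cl)cn2)C1`: in this assay compound 3 gives 7.3

Compound 3 sits lowest of the three numbers. The steps reaching it are a number 0.50 log units lower from compound 1 to compound 3 (beyond the scatter) and a number 0.80 log units lower from compound 2 to compound 3 (beyond the scatter), both beyond the scatter, so the 5-chloropyridin-2-yl ring on the ring nitrogen costs a modest amount against either phenyl variant. Among the measured compounds shown here, the one substituent-only step in the set, a number 0.30 log units higher from compound 1 to compound 2 (within the scatter), lies within the scatter.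

The next compound, compound 4 `Cc1ccc(N2CC[C@@H](NC(=O)Nc3ccccc3Br)C2)nc1`, keeps the core of compound 3 and changes only one group: methyl in place of chloro on an aromatic carbon

For the measured compounds named here, no measured step exchanges chloro for methyl, so the expectation rests on analogy alone. Going by the values given here, the only small substituent change available, from compound 1 to compound 2, stayed within the scatter, and the change here is likewise a single heavy atom for a single heavy atom at the same place on the ring. The step of a number 0.10 log units lower from compound 3 to compound 4 (within the scatter) in this assay is therefore expected to be small, with no direction beyond the scatter called. For compound 4 the estimate in this assay is 7.2, within a range of 6.6 to 7.8.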

Compound 4, negative logarithm of the antagonist equilibrium constant: < 6.7
Compound 4 ended at the assay's limit (the forecaster's own chance of this, stated with the estimate: 5%); middle value at least 0.50 log units from the limit.
By their numbers in this assay, from the lowest: compound 3; then compounds 1 and 2 (each within the scatter of the next). At a limit, below all of these: compound 4.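

In this assay compound 4 stands at a limit of the assay, not at a number: the limit of < 6.7 in this assay, at which 1 of the 4 values shown sits.

Chloro and methyl each count as 1 heavy atom with no hydrogen-bond donors or acceptors, yet the exchange at this place on the six-membered aromatic ring with 1 nitrogen is not silent: a number at least 0.60 log units lower from compound 3 to compound 4 (beyond the scatter). The 5-methylpyridin-2-yl ring also gives large steps against both phenyl variants, a number at least 1.40 log units lower from compound 2 to compound 4 (beyond the scatter) and a number at least 1.10 log units lower from compound 1 to compound 4 (beyond the scatter), where the 5-chloropyridin-2-yl ring gave modest ones.

On these data alone, with a limit in place of a number, the full size of all three steps stays open. As far as these compounds go, how a nitrile, a methoxy or a trifluoromethyl group at this place would read, and whether a methyl on the phenyl variants would cost as much, also stays open.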